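The compounds below may be only part of what the source reports. "The series", "measured", "known", "first", "only" and "open" are said of these compounds alone.

In a functional assay on SK-OV-3 cells (Homo sapiens) for inhibition, read by MTT assay (a higher number here means a weaker inhibitor, a lower number a stronger inhibitor), three compounds built on one shared core have been measured so far. Compound 3, `COc1ccc(/C=C2\c3cc(OC)c(OC)c(OC)c3CC[C@H]2O)cc1C(N)=O`, gives 1920 nM, and compound 2, `COc1ccc(/C=C2\c3cc(OC)c(OC)c(OC)c3CC[C@H]2O)cc1O`, gives 1590 nM, so these two cannot be told apart. Compound 1, `COc1ccc(/C=C2\c3cc(OC)c(OC)c(OC)c3CC[C@@H]2O)cc1C`, gives 730 nM, a clearly lower number, which places compound 3 alongside compound 2 at the high end of this small set.

The next compound is compound 4, `COc1ccc(/C=C2\c3cc(OC)c(OC)c(OC)c3CC[C@H]2O)cc1C`, which puts methyl in place of carbamoyl on an aromatic carbon. Among the measured compounds shown here, only one measured step involves a swap at this same place, a 1.2-fold higher number from compound 2 to compound 3 (0.08 log units; within the scatter). That single exchange argues against expecting a large step here, although it involved different groups. Compound 1 is the closest guide, as it already carries the methyl, but its carbon bearing the hydroxy group has the opposite handedness. Its value of 730 nM therefore suggests only a modest shift towards a lower number, and the uncertainty remains wide. In this assay, the expected change is small: a 1.7-fold lower number from compound 3 to compound 4 (0.24 log units; within the scatter). For compound 4, the estimated value is 1100 nM, with an expected range of 400 nM to 3000 nM.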

Compound 4, half-maximal inhibitory concentration: 1340 nM
Compound 4: the middle estimate sits 1.2-fold (0.09 log units) below what was measured, within the range that was stated.
By their numbers in this assay, from the lowest: compounds 1, 4, 2 and 3 (each within the scatter of the next, the first and the last beyond it).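

At this aromatic carbon, this assay cannot tell methyl from carbamoyl, with a 1.4-fold lower number from compound 3 to compound 4 (0.16 log units; within the scatter), or methyl from hydroxy, with a 1.2-fold lower number from compound 2 to compound 4 (0.07 log units; within the scatter). Methyl has no hydrogen-bond donor or acceptor, yet it gives no step beyond the scatter against either group, which the earlier exchange of hydroxy for carbamoyl could not show. The stereocentre at the saturated ring carbon can now be read as well, with a 1.8-fold higher number from compound 1 to compound 4 (0.26 log units; within the scatter), also within the scatter, and this step speaks to that one carbon alone because of a single fact: the fact that compounds 1 and 4 differ only in the configuration as drawn

Among the compounds shown here, only three groups have been compared at the aromatic carbon, and what an amine, a carboxylic acid or a longer chain such as propyl would give there remains open. For the compounds shown here, compound 1 is the only compound here drawn S at the saturated ring carbon, and whether that configuration would give a larger step with hydroxy or carbamoyl on the aromatic carbon is also unknown.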